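This account rests on a few compounds, and the source may have more. Where it says the series, first, only, none or still open, it means among the compounds named here.

Measured so far:
- Compound 1, `CCCC(=O)Nc1ccc(Sc2cccc(OC)c2)cc1`: 0.19 nM in an assay on isolated protein for binding affinity to melatonin receptor type 1B (Homo sapiens); a higher number here means a weaker inhibitor, a lower number a stronger inhibitor
- Compound 2, `CCCC(=O)Nc1ccc(Nc2cccc(OC)c2)cc1`: 0.39 nM in this assay

Compound 2 gives the higher of the two numbers in this assay; the number for compound 1 lies lower, and the gap between the two is beyond the usual scatter. Compound 3, `COc1cccc(Nc2ccc(NC(=O)C3CC3)cc2)c1`, departs from compound 2 by cyclopropyl in place of propyl on a carbonyl carbon, a change on the amide side. Among the compounds with values here, no measured step of this kind exists, so the step from compound 2 to compound 3 in this assay is expected to stay within the scatter, without a clear direction: a 1.0-fold higher number from compound 2 to compound 3 (0.01 log units; within the scatter). Compound 3 is therefore expected to give about 0.4 nM in this assay, with a range from 0.15 nM to 1.1 nM.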

Compound 3, inhibition constant: 64 nM
Compound 3: middle estimate off by 160-fold (2.20 log units), on the low side; measured number above the stated range.
By their numbers in this assay, from the lowest: compound 1; then compound 2; then compound 3.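

The amide side of the series is not a neutral place to make changes. In this assay cyclopropyl in place of propyl on a carbonyl carbon gives a 160-fold higher number from compound 2 to compound 3 (2.22 log units; beyond the scatter) even though both groups have 3 heavy atoms and neither carries hydrogen-bond donors or acceptors, so closing the chain into a three-membered ring is the only counted difference. Nothing at hand accounts for the size of this step.

On these data alone, whether ethyl or a longer chain such as butyl on the carbonyl carbon keeps the number of compound 2 remains open. So does whether cyclopropyl has a similar effect on the core of compound 1.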